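The source may hold more compounds than are shown below. What is called first, only, known or untested is meant among the compounds shown, and "the series" means these compounds.

Of the compounds shown here, three built on a shared core have been measured in a functional assay (B cells) with Mus musculus as the target; on this read-out lower numbers stand for an effect already at smaller amounts and higher numbers for an effect only at larger amounts of compound. Compound 1, `Nc1nc(O)c2c(n1)n(C1OC(CO)[C@@H](O)[C@H]1O)c(=O)n2C/C=C/c1ccccc1`, gives 103 uM in this assay, the highest of the three numbers. Compound 2, `C=CCn1c(=S)n(C2OC(COCc3ccccc3)[C@H]3OC(C)(C)O[C@@H]23)c2nc(N)nc(O)c21`, gives 47 uM in this assay, a gap from compound 1 that lies beyond the scatter. Compound 3, `C=CCn1c(=O)n(CCC(CCOCc2ccccc2)CCOCc2ccccc2)c2nc(N)nc(O)c21`, gives 7 uM in this assay, the lowest of the three and far beyond the scatter from compound 1. Compound 4, `COc1ccc(Cn2c(=O)n(C3OC(CO)[C@@H](O)[C@H]3O)c3nc(N)nc(O)c32)cc1`, has not yet been measured. It differs from compound 1 in one place: 4-methoxyphenyl in place of 2-phenylethenyl on a saturated chain carbon bound to an aromatic nitrogen. The group that leaves and the group that enters match in heavy-atom count and each carries one six-membered aromatic ring of carbon only; the entering group brings one hydrogen-bond acceptor where the leaving group had none. Among the measured compounds shown here, no measured pair shows this change, so there is no step to lean on. The expected step of a 1.3-fold lower number from compound 1 to compound 4 (0.11 log units; within the scatter) is therefore small, and it may not reach beyond the scatter in either direction. Compound 4 is estimated at 80 uM, within 25 uM to 250 uM.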

Compound 4, concentration for half-maximal effect: 135 uM
Estimate against measurement, compound 4: 1.7-fold (0.23 log units) below; the range from low to high includes it.
By their numbers in this assay, from the lowest: compound 3; then compound 2; then compounds 1 and 4 (each within the scatter of the next).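

Exchanging 2-phenylethenyl for 4-methoxyphenyl on a saturated chain carbon bound to an aromatic nitrogen gives a 1.3-fold higher number from compound 1 to compound 4 (0.12 log units; within the scatter) in this assay, so this single exchange leaves the read-out within the usual scatter. The pair thus shows that, on the core of compound 1, this place can lose the double bond outside aromatic rings and gain a hydrogen-bond acceptor with no measurable shift, provided the group still carries a six-membered aromatic ring of carbon and the same heavy-atom count. No supporting information is available that could explain this outcome.

From the compounds shown here alone, both groups in this pair carry that same kind of ring, so it remains open whether a group without one, such as a simple amine or a carboxylic acid, would move the number beyond the scatter. Going by these compounds, it is also open whether the same exchange would read the same way on a different core.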